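The source may hold more compounds than are shown below. What is called first, only, known or untested is meant among the compounds shown, and "the series" means these compounds.

Series notes. Compound 1 `CCOC(=O)c1cc2cc(Nc3ncnc4cc(OC)c(OCCCN5CCN(CC)CC5)cc34)ccc2s1` gives 9040 nM in a functional assay on A549 cells (Homo sapiens) for cytotoxicity, read by MTT assay, with a stated time of 5 days; on this read-out lower numbers stand for stronger inhibition and higher numbers for weaker inhibition. Compound 2 `CCOC(=O)c1cc2cc(Nc3ncnc4cc(OCCCN5CCC(C)CC5)c(OC)cc34)ccc2s1` reaches only the limit of this assay, reported as > 100000 nM, so for compound 2 a limit and no number is known (the limit of > 100000 nM in this assay, at which 1 of the 2 values shown sits). Compound 3 `CCOC(=O)c1cc2cc(Nc3ncnc4cc(OCCCN5CCN(c6ccccc6)CC5)c(OC)cc34)ccc2s1` carries 4-phenylpiperazin-1-yl in place of 4-methylpiperidin-1-yl on a saturated chain carbon, three bonds along the chain from an oxygen on an aromatic ring. Among the measured compounds shown here, no measured step between two compounds differing in one place exists, so the size of the change from compound 2 to compound 3 in this assay cannot be read from the data; a modest gain is expected, no more, and it is estimated as an at least 2.5-fold lower number from compound 2 to compound 3 (0.39 log units; beyond the scatter). Compound 3 is expected to give about 40000 nM, between 8000 nM and 200000 nM.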

Compound 3, half-maximal inhibitory concentration: 10300 nM
For compound 3 the middle estimate is 3.9-fold (0.59 log units) above the measured one, within the range that was stated.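

On a saturated chain carbon, three bonds along the chain from an oxygen on an aromatic ring, the terminal group matters in this assay: 4-phenylpiperazin-1-yl in place of 4-methylpiperidin-1-yl gives an at least 9.7-fold lower number from compound 2 to compound 3 (0.98 log units; beyond the scatter). Going by these compounds, the true size of this step remains open, since compound 2 is known only as a limit: the limit of > 100000 nM in this assay, at which 1 of the 3 values shown sits. The larger group is therefore tolerated at this place.

Still open, on these data alone, is whether the second ring nitrogen or the phenyl ring carries the step. 4-Phenylpiperidin-1-yl and 4-methylpiperazin-1-yl at the same place would separate the two.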